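Extending the Chain from Compound 3 to Compound 4

The compounds below may be only part of what the source reports. "The series", "measured", "known", "first", "only" and "open" are said of these compounds alone.

Of the compounds shown here, three have so far been measured in an assay on cells (Oocyte) for inhibition of pannexin-1 (Mus musculus), read by voltage clamp, tested at 50 uM, in the presence of a further agent that is not named here; on this read-out lower numbers stand for less inhibition and higher numbers for more inhibition at the one concentration tested (going by the name of the read-out). Compound 1 `O=C(O)c1ccc(Cn2c(C(=O)O)cc3cc(S(=O)(=O)N(Cc4ccccc4)Cc4ccccc4)ccc32)cc1` gives 100%, compound 2 `O=C(O)c1cc2cc([N+](=O)[O-])ccc2n1Cc1ccccc1` gives 51.3%, and compound 3 `O=C(O)c1cn(CCCc2ccccc2)c2ccc([N+](=O)[O-])cc12` gives 71%. Compound 3 therefore stands second highest of the three: compound 2 is its nearest neighbour, with a number beyond the scatter below it, while compound 1 lies furthest away, beyond the scatter above it. Compound 4 `O=C(O)c1cn(CCCCc2ccccc2)c2ccc([N+](=O)[O-])cc12` has not yet been measured; it differs from compound 3 in one place: benzyl in place of phenyl on a saturated chain carbon, three bonds along the chain from an aromatic nitrogen. Within the data shown here, no measured pair shows this change, so its effect in this assay is unknown; a small step in either direction, or none beyond the scatter, is expected. Compound 4 is estimated at 72%, with a range from 55% to 88%. The step expected a number 1 percentage points higher from compound 3 to compound 4 (within the scatter) is thus judged small.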

Compound 4, a percentage reported as inhibition, at one concentration (the size of the read-out at that concentration, not a potency): 65.7%
For compound 4 the middle estimate is 6.3 percentage points above the measured one; measured number inside the range.
By their numbers in this assay, from the lowest: compound 2; then compounds 4 and 3 (each within the scatter of the next); then compound 1.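

In this assay, among these compounds, the change of phenyl to benzyl on a saturated chain carbon, three bonds along the chain from an aromatic nitrogen, gives a number 5.3 percentage points lower from compound 3 to compound 4 (within the scatter) and is the first step read at this place. On this one pair, extending the chain leaves the inhibition unchanged within the scatter, so this position accepts the added carbon without a clear loss or gain. No measurement on hand offers a reason for this step.

As far as these compounds go, whether a longer chain would behave the same remains open. So does the effect of an amine or a carboxylic acid on the phenyl group at the end of the chain.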